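The source may hold more compounds than are shown below. What is called first, only, known or untested is meant among the compounds shown, and "the series" means these compounds.

Measured in a functional assay on LoVo cells (Homo sapiens) for inhibition, read by MTT assay, with a stated time of 24 h (a higher number here means a weaker inhibitor, a lower number a stronger inhibitor), so far
- compound 1 `Cc1ccc(-n2cc(CN3C(=O)C[C@@H]4CC[C@@]3(C)C4(C)C)nn2)cc1` gives 50 nM
- compound 2 `Cc1ccccc1-n1cc(CN2C(=O)C[C@@H]3CC[C@@]2(C)C3(C)C)nn1` gives 80 nM
- compound 3 `COc1ccc(-n2cc(CN3C(=O)C[C@@H]4CC[C@@]3(C)C4(C)C)nn2)cc1` gives 70 nM

Compound 3 stands within the scatter of both others, the gaps being a 1.1-fold lower number from compound 2 to compound 3 (0.06 log units; within the scatter) and a 1.4-fold higher number from compound 1 to compound 3 (0.15 log units; within the scatter) in size. Compound 4 `Cc1cccc(-n2cc(CN3C(=O)C[C@@H]4CC[C@@]3(C)C4(C)C)nn2)c1` has 3-methylphenyl in place of 4-methoxyphenyl on an aromatic nitrogen and keeps the shared core. Among the measured compounds shown here, the step of a 1.6-fold higher number from compound 1 to compound 2 (0.20 log units; within the scatter) also changes only this group and likewise stays within the scatter, so all three measured steps are small. For the measured compounds named here, no compound with 3-methylphenyl has been measured yet. No step beyond the scatter is expected in this assay for this change. The estimated step is a 1.1-fold lower number from compound 3 to compound 4 (0.03 log units; within the scatter) and remains within the scatter. Compound 4 is estimated at 65 nM with an expected range from 35 nM to 120 nM as its likely span.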

Compound 4, half-maximal inhibitory concentration: 50 nM
Compound 4: middle estimate off by 1.3-fold (0.11 log units), on the high side; low and high end bracket the measured number.
By their numbers in this assay, from the lowest: compounds 1, 4, 3 and 2 (each within the scatter of the next).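

Across the three methylphenyl positions, the numbers in this assay show no position effect: the series gives a 1.6-fold lower number from compound 2 to compound 4 (0.20 log units; within the scatter) and also no change at the digits printed from compound 1 to compound 4 (within the scatter) for the exchange on the aromatic nitrogen. Replacing 4-methoxyphenyl gives a 1.4-fold lower number from compound 3 to compound 4 (0.15 log units; within the scatter) and so adds a second small step for a change of both group and position. No measurement available here bears on why these steps stay small.

Still open, from the compounds shown here alone, is whether an amine, a carboxylic acid or a longer chain on this phenyl would give a step beyond the scatter.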